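Series notes: side-chain variation on the shared carbamate core

This account rests on a few compounds, and the source may have more. Where it says the series, first, only, none or still open, it means among the compounds named here.

Among the compounds with values here, compound 2 `O=C(O)c1csc(SCCN2C(=O)OC[C@@H]2/C=C/[C@@H](O)C2(CCc3ccccc3)CCC2)n1` is the weaker of the two measured members of this set. In an assay on isolated protein for agonist activity at prostaglandin E2 receptor EP3 subtype (Homo sapiens) (on this read-out higher numbers stand for an effect only at larger amounts of compound and lower numbers for an effect already at smaller amounts), compound 2 gives 27 nM, while compound 1 `CC(C)(CCCCF)[C@H](O)/C=C/[C@H]1COC(=O)N1CCSc1nc(C(=O)O)cs1` gives 4.7 nM; the gap between them lies beyond the scatter of repeated measurements. Compound 3 `COCCCC1([C@H](O)/C=C/[C@H]2COC(=O)N2CCSc2nc(C(=O)O)cs2)CCC1` is yet to be measured in this assay. It differs from compound 2 in one place: methoxymethyl in place of phenyl on a saturated chain carbon, two bonds along the chain from a saturated ring carbon. Compound 1, with its ether-free but heteroatom-bearing flexible chain, sits at the lower number, so a move away from the aromatic terminus toward a shorter oxygen-containing chain is expected to shift compound 3 toward lower numbers, by a step of a 2.3-fold lower number from compound 2 to compound 3 (0.35 log units; beyond the scatter), probably modest and near the edge of the scatter. Compound 3 is accordingly estimated at 12 nM, within 4 nM to 40 nM.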

Compound 3, half-maximal effective concentration: 25 nM
Compound 3: the middle estimate sits 2.1-fold (0.32 log units) below what was measured; the range from low to high includes it.
By their numbers in this assay, from the lowest: compound 1; then compounds 3 and 2 (each within the scatter of the next).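

In this assay the change to methoxymethyl in place of phenyl on a saturated chain carbon, two bonds along the chain from a saturated ring carbon, is a 1.1-fold lower number from compound 2 to compound 3 (0.03 log units; within the scatter) and so leaves the reading unmoved: at this position the phenyl can be given up without loss. The lower number of compound 1 is therefore not reached by removing the phenyl alone, since replacing 5-fluoro-1,1-dimethylpentyl with 1-(3-methoxypropyl)cyclobutyl is a 5.3-fold higher number from compound 1 to compound 3 (0.73 log units; beyond the scatter) and remains a clear gap. Nothing available gives a reason for either step.

Going by these compounds, whether an amine, a hydroxyl or a longer chain at this position would hold the number of compound 3 remains open. The step from compound 1 also changes the cyclobutyl ring and the chain end together, so their shares cannot be separated.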